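The source may report more compounds than this note shows. Statements on the series, on what has been measured and on what is new or still open speak of the compounds shown alone.

In a functional assay on HUVEC cells (Homo sapiens) for antiproliferative activity, read by MTT assay, with a stated time of 24 h (on this read-out lower numbers stand for stronger inhibition and higher numbers for weaker inhibition), compound 1 (`C=CCc1cc(-c2cccc([N+](=O)[O-])c2)ccc1O`) gives > 100000 nM. That value is a limit, not a number. Within the data shown here, compound 2 (`C=CC(C)(C)c1cc(-c2cccc([N+](=O)[O-])c2)ccc1O`) gives 77000 nM, and the only measured step, an at least 1.2-fold lower number from compound 1 to compound 2 (0.11 log units; that floor lies within the scatter), changes the allyl group itself. Compound 3 (`C=CCc1cc(-c2cccc([N+](=O)[O-])c2)cc(CC=C)c1O`) instead differs from compound 1 by allyl in place of hydrogen on an aromatic carbon, with the new allyl ortho to a hydroxy group. Given the small size of an at least 1.2-fold lower number from compound 1 to compound 2 (0.11 log units; that floor lies within the scatter), only a modest step toward a lower number is expected in this assay, perhaps none beyond the scatter. The estimated step is an at least 1.4-fold lower number from compound 1 to compound 3 (0.15 log units; that floor lies within the scatter). The expected value for compound 3 is 70000 nM, with an estimated range of 25000 nM to 100000 nM.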

Compound 3, half-maximal inhibitory concentration: > 100000 nM
Compound 3: a limit, no number; the forecaster's own chance of this, stated with the estimate: 45%; middle value at least 1.4-fold (0.15 log units) away from the limit.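

Compound 1 and compound 3 both stand at a limit, not a number, so no step between them can be read: the limit of > 100000 nM in this assay, at which 2 of the 3 values shown sit.

Going by these compounds, whether allyl in place of hydrogen changes the number in this assay at all, and in which direction, stays open.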